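Trifluoromethyl for Chloro on a Biphenyl Amide

A few compounds are considered here, and "the series" means these few. Any claim that something is new, unique, unknown or untested is made for them only; others in the source may bear on it.

Compound 1, `CCCc1cc(N2CCCCC2)c2cc(NC(=O)/C=C/c3ccc(C(F)(F)F)cc3)ccc2n1`: > 4000 nM
Compound 2, `CCCc1cc(N)c2cc(NC(=O)c3ccc(-c4ccc(Cl)cc4)cc3)ccc2n1`: 0.7 nM
Compound 3, `CCCc1cc(N)c2cc(NC(=O)/C=C/c3ccc(C(C)(C)C)cc3)ccc2n1`: 22 nM

Three compounds share a core and differ in the group carried by the amide. In an assay on isolated protein for displacement of a labelled ligand from melanin-concentrating hormone receptor 1 (Homo sapiens) (on this read-out lower numbers stand for stronger inhibition and higher numbers for weaker inhibition), compound 2 gives 0.7 nM, the lowest of the two numbers obtained. Compound 3 gives 22 nM in this assay, a much higher number that lies well beyond the scatter of repeated measurements. Compound 1 sits at the limit of > 4000 nM in this assay, at which 1 of the 3 values shown sits; this is a limit set by the assay, not a number.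

The next compound, compound 4, `CCCc1cc(N)c2cc(NC(=O)c3ccc(-c4ccc(C(F)(F)F)cc4)cc3)ccc2n1`, has not yet been measured in this assay. It comes from compound 2 by a single change: trifluoromethyl in place of chloro on an aromatic carbon.

For the measured compounds named here, nothing among the measured compounds shows what this exchange does. No two of them differ only in this way. A chloro group and a trifluoromethyl group on the same aromatic carbon are, by experience with many series, often close in effect, so the expected step is small and may not exceed the scatter. The expected step reads a 2.1-fold higher number from compound 2 to compound 4 (0.33 log units; beyond the scatter). Compound 4 is therefore expected to give about 1.5 nM in this assay, within a range from 0.4 nM to 6 nM.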

Compound 4, half-maximal inhibitory concentration: 4.5 nM
Compound 4: middle estimate off by 3.0-fold (0.48 log units), on the low side, and the stated range covers the measured number.
By their numbers in this assay, from the lowest: compound 2; then compound 4; then compound 3. At a limit, above all of these: compound 1.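

For the compounds shown here, replacing the 4-chlorophenyl with the 4-(trifluoromethyl)phenyl gives the first direct reading of what this aromatic carbon, para to a large group, contributes: in this assay the change produces a 6.4-fold higher number from compound 2 to compound 4 (0.81 log units; beyond the scatter), a modest step but a real one. The exchange swaps one heavy atom for four and leaves the counts of hydrogen-bond donors, hydrogen-bond acceptors and net charge as they were, so the number can shift at this position even when those counts stay the same, and the two groups cannot be treated as interchangeable here. No measurement shown here bears on why the number rises with this exchange.

Going by these compounds alone, only two groups have been seen on this carbon, so it remains open where a fluoro, methyl or methoxy group would fall relative to compound 2 and compound 4, and whether an amine or a carboxylic acid would keep any of the binding at all. Within the data shown here, it is also open whether the same exchange would give a step of similar size on another amide group, since this single pair of compounds gives only one reading of it.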